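The compounds below may be only part of what the source reports. "The series", "measured", "known", "first", "only" and "open" are said of these compounds alone.

In a functional assay on HeLa cells (Homo sapiens) for cytotoxicity, read by XTT assay, with a stated time of 48 h (on this read-out lower numbers stand for stronger inhibition and higher numbers for weaker inhibition), compound 1 (`O=C(O)CC[C@H](NC(=O)N1C/C(=C\c2ccc(Cl)c(Cl)c2)C(=O)/C(=C/c2ccc(Cl)c(Cl)c2)C1)C(=O)O`) gives > 50000 nM, which is a limit. Compound 2 (`NCCCC[C@H](NC(=O)N1C/C(=C\c2ccc(Cl)c(Cl)c2)C(=O)/C(=C/c2ccc(Cl)c(Cl)c2)C1)C(=O)O`) gives > 50000 nM, also a limit, so it stands with no number of its own. Within the data shown here, the one measured step, a step that the two limits leave unreadable from compound 1 to compound 2, offers no size to carry forward, and the evidence is the limit of > 50000 nM in this assay, at which 2 of the 2 values shown sit. Compound 3 (`CC(C)C[C@H](NC(=O)N1C/C(=C\c2ccc(Cl)c(Cl)c2)C(=O)/C(=C/c2ccc(Cl)c(Cl)c2)C1)C(=O)O`) has isopropyl in place of 3-aminopropyl on a saturated chain carbon, two bonds along the chain from an amide-type nitrogen and a carbonyl carbon. With no readable step as a guide, only a modest, uncertain move towards stronger inhibition is expected in this assay, as the estimated at least 1.2-fold lower number from compound 2 to compound 3 (0.09 log units; that floor lies within the scatter). The estimated value for compound 3 is 40000 nM, within a range of 10000 nM to 100000 nM.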

Compound 3, half-maximal inhibitory concentration: 20000 nM
The estimate for compound 3 lay 2.0-fold (0.30 log units) above the measured number; measured number inside the range.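

In this assay, among these compounds, this position gives a readable change for the first time: isopropyl in place of 3-aminopropyl gives an at least 2.5-fold lower number from compound 2 to compound 3 (0.39 log units; beyond the scatter), and isopropyl in place of carboxymethyl gives an at least 2.5-fold lower number from compound 1 to compound 3 (0.39 log units; beyond the scatter). Both steps are only floors, as the compounds they start from stay at a limit: the limit of > 50000 nM in this assay, at which 2 of the 3 values shown sit. Compound 3 is therefore the only one of the three with a number of its own. Still open, as far as these compounds go, is whether a longer hydrocarbon chain or a benzyl group on this saturated chain carbon would move the number further than isopropyl does.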